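The compounds below may be only part of what the source reports. "The series", "measured", "known", "first", "only" and "open" are said of these compounds alone.

Compound 1 `N=C1S/C(=C\c2ccc(OCc3ccccc3)cc2)C(=O)N1c1ccc(F)cc1` gives 10.5% in an ADME assay on RAW264.7 cells (Mus musculus) for cytotoxicity, read by MTT assay, with a stated time of 48 h, tested at 50 uM (on this read-out lower numbers stand for less inhibition and higher numbers for more inhibition at the one concentration tested (going by the name of the read-out)), the lowest of the three numbers recorded there. Compound 2 `N=C1S/C(=C\c2ccc(OCc3ccccc3)cc2)C(=O)N1c1cccc([N+](=O)[O-])c1` gives 52.9%, and compound 3 `N=C1S/C(=C\c2ccc(OCc3ccccc3)cc2)C(=O)N1c1ccc(Cl)cc1Cl` gives 13.8%. The change to compound 4 `N=C1S/C(=C\c2ccc(OCc3ccccc3)cc2)C(=O)N1c1ncccn1` is pyrimidin-2-yl in place of 4-fluorophenyl on an amide-type nitrogen in a ring. Two measured steps replace the same 4-fluorophenyl group on the amide-type nitrogen in the ring: the step of a number 42.4 percentage points higher from compound 1 to compound 2 (beyond the scatter) is large, while the step of a number 3.3 percentage points higher from compound 1 to compound 3 (within the scatter) stays within the scatter. Neither involves a pyrimidin-2-yl group, so the direction for compound 4 rests on weak footing. Compound 4 is expected to give 20%, between 5% and 45%, which means an estimated step of a number 9.5 percentage points higher from compound 1 to compound 4 (within the scatter).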

Compound 4, a percentage reported as inhibition, at one concentration (the size of the read-out at that concentration, not a potency): 26.6%
Compound 4: middle estimate off by 6.6 percentage points, on the low side; the measured number falls inside the stated range.
By their numbers in this assay, from the lowest: compounds 1 and 3 (each within the scatter of the next); then compound 4; then compound 2.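

With pyrimidin-2-yl on the amide-type nitrogen in a ring, this assay shows a step of a number 16.1 percentage points higher from compound 1 to compound 4 (beyond the scatter) and a step of a number 12.8 percentage points higher from compound 3 to compound 4 (beyond the scatter) but also a step of a number 26.3 percentage points lower from compound 2 to compound 4 (beyond the scatter) in the same series. This position therefore gives a third level, since a ring with 2 hetero atoms separates from both 4-fluorophenyl and 2,4-dichlorophenyl without reaching 3-nitrophenyl. Nothing measured here accounts for that level. Open, as far as these compounds go, is how a pyridin-2-yl group, with one ring nitrogen, would compare at this position. So is whether a phenyl ring bearing a carboxylic acid or an amine would stay near compound 4 or compound 2.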